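The source may hold more compounds than are shown below. What is called first, only, known or untested is meant among the compounds shown, and "the series" means these compounds.

Measured compounds:
compound 1 `CCC1CCN(c2nc(C(C)(C)C)ccc2CNC(=O)C(C)c2ccc(NS(C)(=O)=O)c(F)c2)CC1` gives 0.1 nM
compound 2 `CC(C)CCOc1nc(C(C)(C)C)ccc1CNC(=O)C(C)c1ccc(NS(C)(=O)=O)c(F)c1` gives 0.8 nM
compound 3 `CC(C(=O)NCc1ccc(C(C)(C)C)nc1OC1CCCCC1)c1ccc(NS(C)(=O)=O)c(F)c1` gives 2.5 nM

All three were tested in an assay on cells for antagonist activity at transient receptor potential cation channel subfamily V member 1 (Homo sapiens), read by FLIPR and calcium flux, with a stated time of 6 min; on this read-out lower numbers stand for stronger inhibition and higher numbers for weaker inhibition. Compound 1 stands lowest of the three numbers, so it is the strongest inhibitor of this set; compound 2 is nearest to it and compound 3 furthest.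

Compound 4 `CCCCCc1nc(C(C)(C)C)ccc1CNC(=O)C(C)c1ccc(NS(C)(=O)=O)c(F)c1` has not yet been measured. It differs from compound 1 in one place: pentyl in place of 4-ethylpiperidin-1-yl on an aromatic carbon. The pentyl chain carries no ring and no hydrogen-bond acceptor, and it sits next to the ring nitrogen, where the 4-ethylpiperidin-1-yl group stood.

Going by the values given here, two measured steps bear on this change, both departing from compound 1 at the same aromatic carbon. Swapping the 4-ethylpiperidin-1-yl group for isopentyloxy gave an 8.0-fold higher number from compound 1 to compound 2 (0.90 log units; beyond the scatter), and for cyclohexyloxy gave a 25-fold higher number from compound 1 to compound 3 (1.40 log units; beyond the scatter). Both replacements weakened inhibition beyond the scatter, so a step in the same direction, of modest size, is expected here as well: a 10-fold higher number from compound 1 to compound 4 (1.00 log units; beyond the scatter). Compound 4 is therefore estimated at 1 nM, with a likely range from 0.2 nM to 5 nM.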

Compound 4, inhibition constant: 1.9 nM
Compound 4: the middle estimate sits 1.9-fold (0.28 log units) below what was measured; measured number inside the range.
By their numbers in this assay, from the lowest: compound 1; then compound 2; then compounds 4 and 3 (each within the scatter of the next).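

Even with no oxygen link, the pentyl chain falls well short of the 4-ethylpiperidin-1-yl group, with a 19-fold higher number from compound 1 to compound 4 (1.28 log units; beyond the scatter), so the loss at this aromatic carbon is not confined to groups attached through oxygen. Against those oxygen-linked groups the result is split, with a 2.4-fold higher number from compound 2 to compound 4 (0.38 log units; beyond the scatter) but a 1.3-fold lower number from compound 3 to compound 4 (0.12 log units; within the scatter). Among these four compounds the 4-ethylpiperidin-1-yl group alone gives a sub-nanomolar-scale advantage over every other group, yet nothing available explains why.

The compounds shown leave open whether the ring, its nitrogen or the ethyl group matters most, which a 4-ethylcyclohexyl group or an unsubstituted piperidin-1-yl group would help to separate. They also leave open how an open-chain amine such as diethylamino or a shorter chain such as propyl would compare at this carbon.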